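Removing the naphthalenyl group from a spirocyclic thiophene sigma ligand

The source may hold more compounds than are shown below. What is called first, only, known or untested is meant among the compounds shown, and "the series" means these compounds.

Measured compounds:
- compound 1, `O=[N+]([O-])c1ccc(-c2scc3c2CCOC32CCN(Cc3ccccc3)CC2)cc1`, 1.7 nM
- compound 2, `COC1Cc2c(csc2-c2cccc3ccccc23)C2(CCN(Cc3ccccc3)CC2)O1`, 5 nM
- compound 3, `COC1Cc2cc(-c3cccc4ccccc34)sc2C2(CCN(Cc3ccccc3)CC2)O1`, 12 nM

In an assay on membranes from brain for displacement of a labelled ligand from Sigma non-opioid intracellular receptor 1 (Cavia porcellus), read by scintillation counting, with a stated time of 120 min (on this read-out higher numbers stand for weaker inhibition and lower numbers for stronger inhibition), compound 3 gives the highest of the three numbers; compound 2 sits beyond the scatter below it, and compound 1 lies furthest below. Compound 4, `COC1Cc2ccsc2C2(CCN(Cc3ccccc3)CC2)O1`, has not been measured in this assay. It differs from compound 3 in one place: hydrogen in place of naphthalen-1-yl on an aromatic carbon. For the measured compounds named here, no step between measured compounds isolates this change, so the account rests on the three values alone. All three measured compounds carry an aromatic group on the five-membered ring, and losing it is expected to weaken binding in this assay, a step estimated as a 3.3-fold higher number from compound 3 to compound 4 (0.52 log units; beyond the scatter). For compound 4 the estimated value in this assay is 40 nM, within a range of 8 nM to 200 nM.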

Compound 4, inhibition constant: 1.9 nM
For compound 4 the middle estimate is 21-fold (1.32 log units) above the measured one; measured number outside the range, below it.
By their numbers in this assay, from the lowest: compounds 1 and 4 (each within the scatter of the next); then compound 2; then compound 3.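

In this assay hydrogen in place of naphthalen-1-yl on the aromatic carbon next to the ring sulfur gives a 6.3-fold lower number from compound 3 to compound 4 (0.80 log units; beyond the scatter) and so strengthens binding rather than weakening it. Compound 4 gives 1.9 nM with only hydrogen on this carbon, so in this series binding does not depend on an aromatic group at this position. Nothing shown here accounts for the change.

As far as these compounds go, it remains open whether a methyl group or a phenyl ring on this carbon would read closer to compound 3 or to compound 4. From the compounds shown here alone, how an amine at the same place would read also remains open.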